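The source may report more compounds than this note shows. Statements on the series, on what has been measured and on what is new or still open speak of the compounds shown alone.

Measured so far:
- compound 1, `O=C1CSC(c2c(Cl)cccc2Cl)N1CCN1CCCCC1`: 100%
- compound 2, `O=C1CSC(c2cccc(O)c2)N1CCN1CCCCC1`: 100%

In an ADME assay on Vero cells (Chlorocebus sabaeus) for cytotoxicity, read by neutral red uptake, tested at 49 ug/mL (a higher number here means a weaker effect of the compound at the concentration tested, a lower number a stronger effect), compound 1 gives 100%. In this assay compound 2 gives 100%, level with compound 1 at the digits shown and within the usual scatter of the measurement; on the numbers available the two compounds are not told apart. Among the compounds with values here, no step between measured compounds is on hand for this series.

The next compound, compound 3, is `O=C1CSC(c2ccc(Cl)cc2)N1CCN1CCCCC1`. Against compound 2 the change is 4-chlorophenyl in place of 3-hydroxyphenyl on a saturated ring carbon. Compound 1 and compound 2 already carry different aromatic substituents on the same saturated ring carbon and show the same read-out, so the expectation for compound 3 is no step beyond the scatter: the estimated change no change at the digits printed from compound 2 to compound 3 (within the scatter) is essentially none. Compound 3 is expected to give 100% in this assay, with a range from 85% to 100%.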

Compound 3, a percentage reported as activity, at one concentration (the size of the read-out at that concentration, not a potency): 84%
For compound 3 the middle estimate is 16 percentage points above the measured one; the measured number lies below the stated range.
By their numbers in this assay, from the lowest: compound 3; then compounds 1 and 2 (each within the scatter of the next).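

In this assay the aromatic group on this saturated ring carbon can shift the read-out: 4-chlorophenyl in place of 3-hydroxyphenyl gives a number 16 percentage points lower from compound 2 to compound 3 (beyond the scatter). Within the data shown here, the level shared by the earlier compounds therefore does not hold for every aromatic substituent here, and chlorine alone does not go with the lower number, since compound 1, which also carries chlorine, gives 100%. No measurement on hand bears on the origin of this step.

On these data alone, whether the step goes with the chlorine or with its place on the phenyl ring stays open; the two change together in this single step. Also open, as far as these compounds go, is how an unsubstituted phenyl, or a phenyl carrying an amine or a carboxylic acid, would read at this carbon.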